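The source may report more compounds than this note shows. Statements on the series, on what has been measured and on what is new or still open speak of the compounds shown alone.

In an assay on RMS13 cells for displacement of a labelled ligand from Urotensin-2 receptor (Homo sapiens), read by scintillation proximity assay (on this read-out lower numbers stand for stronger inhibition and higher numbers for weaker inhibition), compound 2 `COc1ccc([C@@H](CCCN(C)S(=O)(=O)c2cccs2)N2Cc3c(cccc3N3CCN(C4CCC4)CC3)C2=O)cc1OC` gives 44 nM, the lowest of the two numbers measured, and compound 1 `CCN1CCN(c2cccc3c2C(=O)N([C@H](CCCNS(=O)(=O)c2cn(C)c(C)n2)c2ccc(OC)c(OC)c2)C3=O)CC1` gives 97 nM, a higher number that lies beyond the usual scatter. Compound 3 `CCN1CCN(c2cccc3c2CN([C@H](CCCN(C)S(=O)(=O)c2cccs2)c2ccc(OC)c(OC)c2)C3=O)CC1` differs from compound 2 in one place: ethyl in place of cyclobutyl on an amine nitrogen in a ring. Going by the values given here, with no step between measured compounds to lean on, a change of this small size is expected to move the number only modestly, if at all, toward weaker binding. For compound 3 the estimated step of a 1.6-fold higher number from compound 2 to compound 3 (0.20 log units; within the scatter) in this assay leads to an expected value of 70 nM, within a range from 25 nM to 200 nM.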

Compound 3, inhibition constant: < 5 nM
Compound 3: only a limit was reported; the forecaster's own chance of this, stated with the estimate: 2%; at least 14-fold (1.14 log units) between middle value and limit.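

In this assay, ethyl in place of cyclobutyl on the amine nitrogen of the six-membered non-aromatic ring gives an at least 8.8-fold lower number from compound 2 to compound 3 (0.94 log units; beyond the scatter). This is the first one-place comparison among the compounds shown, and it marks this nitrogen as a place where a small change of group moves binding well beyond the scatter. Compound 3 has only a limit, so the step gives a minimum size and its full size stays unknown: the limit of < 5 nM in this assay, at which 1 of the 3 values shown sits.

The compounds shown leave open how methyl, isopropyl or a bare amine hydrogen on that nitrogen would compare. They also leave open whether ethyl gives a similar step with other sulfonamide groups.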